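Solubility of compound 4 against three measured analogues

A few compounds are considered here, and "the series" means these few. Any claim that something is new, unique, unknown or untested is made for them only; others in the source may bear on it.

Measured compounds:
- compound 1 `O=C1c2ccccc2CN1c1cnc(NCc2c(F)ccc3c2CCO3)n2cnnc12`: 4000 nM
- compound 2 `CN(c1ncco1)c1cnc(NCc2c(F)ccc3c2CCO3)n2cnnc12`: 67000 nM
- compound 3 `Fc1ccc2c(c1CNc1ncc(Nc3ccccc3)c3nncn13)CCO2`: 3000 nM

In a physicochemical assay for solubility, read by LC-MS, in phosphate buffer, with a stated time of 24 h, at pH 7.4 (a higher number here means a more soluble compound, a lower number a less soluble compound), compound 3 gives 3000 nM, the lowest of the three numbers, though its gap to compound 1 is small: a 1.3-fold lower number from compound 1 to compound 3 (0.12 log units; within the scatter). Only compound 2 stands clearly apart, with a 22-fold lower number from compound 2 to compound 3 (1.35 log units; beyond the scatter).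

Compound 4 `CN(C(=O)c1ccccc1)c1cnc(NCc2c(F)ccc3c2CCO3)n2cnnc12` is the untested member. It differs from compound 3 in one place: benzoyl(methyl)amino in place of anilino on an aromatic carbon

Among the measured compounds shown here, two measured steps bear on this change. For the measured compounds named here, the step of a 22-fold lower number from compound 2 to compound 3 (1.35 log units; beyond the scatter) shows that replacing the anilino group can move the number a long way, but the group entering in compound 4 is not the one carried by compound 2. Closer in kind is compound 1, which also carries a group of 10 heavy atoms with 1 oxygen on the same carbon of the core, and there the step of a 1.3-fold lower number from compound 1 to compound 3 (0.12 log units; within the scatter) stayed within the scatter. The step into compound 4 is therefore expected to be small, at most a modest rise in this assay: a 2.0-fold higher number from compound 3 to compound 4 (0.30 log units; within the scatter). Compound 4 is estimated at 6000 nM, within a range of 2000 nM to 20000 nM.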

Compound 4, solubility: 280000 nM
For compound 4 the middle estimate is 47-fold (1.67 log units) below the measured one, outside the stated range (above it).
By their numbers in this assay, from the lowest: compounds 3 and 1 (each within the scatter of the next); then compound 2; then compound 4.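

In this assay, among the compounds shown here, putting benzoyl(methyl)amino in place of anilino on this aromatic carbon gives a 93-fold higher number from compound 3 to compound 4 (1.97 log units; beyond the scatter), so this position can carry a far larger rise than the earlier compounds showed. The size of the entering group does not settle the number, since compound 1 and compound 4 both carry a group of 10 heavy atoms here, yet the step is a 70-fold higher number from compound 1 to compound 4 (1.85 log units; beyond the scatter). With the methyl-bearing nitrogen kept and only the group on it exchanged, benzoyl in place of 1,3-oxazol-2-yl gives a 4.2-fold higher number from compound 2 to compound 4 (0.62 log units; beyond the scatter), and among these four compounds the two with that nitrogen stand clearly above the other two.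

Nothing measured here accounts for these rises. Also open, going by these compounds, is what the amide hydrogen in place of the methyl, or an aliphatic amine on the benzoyl ring, would do at this position.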